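The compounds below may be only part of what the source reports. "The series", "measured", "known", "first", "only" and "open" are said of these compounds alone.

Measured in a functional assay on HCT-116 cells (Homo sapiens) for antiproliferative activity, read by MTT assay, with a stated time of 72 h; on this read-out lower numbers stand for stronger inhibition and higher numbers for weaker inhibition:
- Compound 1 `CC(=O)c1ccc(-c2cccc(NC(=O)CCc3ccc4c(c3)B(O)OC4)c2)cc1`: 19000 nM
- Compound 2 `CC(=O)c1ccc(-c2cccc(NC(=O)CCc3ccc4c(c3)COB4O)c2)cc1`: 63000 nM
- Compound 3 `CC(=O)c1ccc(-c2cccc(NC(=O)CCc3cccc4c3COB4O)c2)cc1`: 48000 nM

On these numbers, compound 3 sits in the upper pair. The gap within that pair is a 1.3-fold lower number from compound 2 to compound 3 (0.12 log units; within the scatter), and the comparison with the remaining compound is a 2.5-fold higher number from compound 1 to compound 3 (0.40 log units; beyond the scatter).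

The next case is compound 4 `CC(=O)c1ccc(-c2cccc(NC(=O)CCc3ccccc3)c2)cc1`, which departs from compound 3 by this change: a group of 6 heavy atoms (6 carbon; one six-membered aromatic ring of carbon only) in place of a group of 10 heavy atoms (7 carbon, 1 boron, 2 oxygen; one five-membered non-aromatic ring with 2 hetero atoms, one six-membered aromatic ring of carbon only), on a saturated chain carbon, two bonds along the chain from a carbonyl carbon.

Within the data shown here, no measured step makes this change. The three steps in hand only exchange one group for another of the same counted make-up, and the largest of them, a 3.3-fold higher number from compound 1 to compound 2 (0.52 log units; beyond the scatter), is modest. Among the measured compounds shown here, they show how far this assay moves when the group is rearranged, not when it is replaced by phenyl, so they give no direction for this step. No step beyond the scatter is therefore expected, though the uncertainty is wide.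

Compound 4 is expected at about 50000 nM, with an estimated range of 20000 nM to 130000 nM.

This estimate corresponds to an expected 1.0-fold higher number from compound 3 to compound 4 (0.02 log units; within the scatter).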

Compound 4, half-maximal inhibitory concentration: 4000 nM
For compound 4 the middle estimate is 13-fold (1.10 log units) above the measured one; the whole stated range lies above it.
By their numbers in this assay, from the lowest: compound 4; then compound 1; then compounds 3 and 2 (each within the scatter of the next).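

In this assay, putting phenyl in place of the boron-bearing group of 10 heavy atoms, on a saturated chain carbon, gives a 12-fold lower number from compound 3 to compound 4 (1.08 log units; beyond the scatter), a 16-fold lower number from compound 2 to compound 4 (1.20 log units; beyond the scatter) and a 4.8-fold lower number from compound 1 to compound 4 (0.68 log units; beyond the scatter). All three steps run the same way and lie beyond the scatter, and each is larger than the biggest step seen on rearranging the boron-bearing group, a 3.3-fold higher number from compound 1 to compound 2 (0.52 log units; beyond the scatter), so at this place removing that group moves the number more than rearranging it does. Nothing available bears on why this happens.

The compounds shown do not tell whether phenyl itself is the best group at this place, or how a pyridine ring, a phenyl ring carrying an amine or a carboxylic acid, or a longer chain would compare. They also leave open whether the same step would appear on a different core.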